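This account rests on a few compounds, and the source may have more. Where it says the series, first, only, none or still open, it means among the compounds named here.

The compounds here share one core, shown in compound 2 `COc1ccc(C(=O)/C=C/c2cccc(F)c2)c2c1C=CC(C)(C)O2`. In a functional assay on HCT-116 cells (Homo sapiens) for antiproliferative activity, read by MTT assay, with a stated time of 24 h (on this read-out higher numbers stand for weaker inhibition and lower numbers for stronger inhibition), compound 2 gives only a limit, > 10000 nM. Compound 1 `COc1cc(OC)c(OC)cc1/C=C/C(=O)c1ccc(OC)c2c1OC(C)(C)C=C2` likewise reaches only a limit in this assay, > 10000 nM. Compound 3 `COc1ccc(C(=O)/C=C/c2ccc(N(c3ccccc3)c3ccccc3)cc2)c2c1C=CC(C)(C)O2` also stops at a limit in this assay, > 10000 nM. So every value so far rests at the limit of > 10000 nM in this assay, at which 3 of the 3 values shown sit, and compound 2 stands level with the others, with no number to set it apart.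

Compound 4 `COc1ccc(C(=O)/C=C/c2ccc(O)c(Br)c2)c2c1C=CC(C)(C)O2` has not yet been measured in this assay. It differs from compound 2 in one place: 3-bromo-4-hydroxyphenyl in place of 3-fluorophenyl on a double-bonded chain carbon bound to a double-bonded chain carbon. Among the compounds with values here, no pair of measured compounds differs in a single place, so no measured step gives a scale for this change. Because all three values sit at the limit of > 10000 nM in this assay, at which 3 of the 3 values shown sit, the shown numbers offer no direction for the step from compound 2 to compound 4. The expected step is therefore none beyond the scatter, written as a number no higher from compound 2 to compound 4 (the limit leaves the size open). Compound 4 is expected to give about 10000 nM in this assay, within a range from 2000 nM to 50000 nM, and most likely again reported only as a limit.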

Compound 4, half-maximal inhibitory concentration: > 10000 nM
Compound 4 was reported as a limit; the forecaster's own chance of this, stated with the estimate: 70%; the middle value lies on the limit itself.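

Compound 2 and compound 4 both stop at a limit in this assay, so the change between them has no readable size: the limit of > 10000 nM in this assay, at which 4 of the 4 values shown sit. The compounds shown leave open whether any change on the shared core gives an actual number in this assay.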